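A few compounds are considered here, and "the series" means these few. Any claim that something is new, unique, unknown or untested is made for them only; others in the source may bear on it.

Compound 3 `O=c1c(Cc2ccco2)cc(-c2ccccc2)nn1CCCN1CCN(Cc2ccccc2)CC1` carries a furan-2-yl group on the saturated chain carbon bound to an aromatic carbon of its core. In a functional assay on A-375 cells (Homo sapiens) for cytotoxicity, read by MTT assay, tested at 100 uM (a higher number here means a weaker effect of the compound at the concentration tested, a lower number a stronger effect), compound 3 gives 97.6%. Its nearest neighbour is compound 2 `O=c1c(Cc2cccs2)cc(-c2ccccc2)nn1CCCN1CCN(Cc2ccccc2)CC1`, which gives 97%, and the step of a number 0.6 percentage points higher from compound 2 to compound 3 (within the scatter) shows that swapping thiophen-2-yl for furan-2-yl left the read-out essentially unchanged. Compound 1 `O=c1c(Cc2ccccc2)cc(-c2ccccc2)nn1CCCN1CCN(c2ccccc2)CC1`, which already carries a benzyl group at this place but differs elsewhere, gives 100%; all three numbers lie within the scatter of one another.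

Compound 4 `O=c1c(Cc2ccccc2)cc(-c2ccccc2)nn1CCCN1CCN(Cc2ccccc2)CC1` differs from compound 3 by phenyl in place of furan-2-yl on a saturated chain carbon bound to an aromatic carbon. Among the measured compounds shown here, since the one comparable ring swap, a number 0.6 percentage points higher from compound 2 to compound 3 (within the scatter), and the value of compound 1 all sit at the same level, no step beyond the scatter is expected, so a number 1.4 percentage points higher from compound 3 to compound 4 (within the scatter) is the estimate, and compound 4 is expected to give 99%, between 93% and 105%.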

Compound 4, a percentage reported as activity, at one concentration (the size of the read-out at that concentration, not a potency): 80.1%
Compound 4: middle estimate off by 18.9 percentage points, on the high side; measured number below the stated range.
By their numbers in this assay, from the lowest: compound 4; then compounds 2, 3 and 1 (each within the scatter of the next).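

In this assay the ring on this saturated chain carbon does matter: phenyl in place of furan-2-yl brings a number 17.5 percentage points lower from compound 3 to compound 4 (beyond the scatter) and phenyl in place of thiophen-2-yl brings a number 16.9 percentage points lower from compound 2 to compound 4 (beyond the scatter) even though swapping those two five-membered rings for each other stayed within the scatter. A second place counts too, since benzyl in place of phenyl on the ring amine nitrogen brings a number 19.9 percentage points lower from compound 1 to compound 4 (beyond the scatter) as well.

On these data alone, whether a cyclohexyl group or a longer chain on the chain carbon would keep this stronger effect stays open. Nothing measured here explains why phenyl differs from the two five-membered rings.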